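This account rests on a few compounds, and the source may have more. Where it says the series, first, only, none or still open, it means among the compounds named here.

Measured so far:
Compound 1, `CCCc1nnc([S+]([O-])Cc2ncc(C)c(OC)c2C)o1`: 10000 nM
Compound 2, `[O-][S+](Cc1ccccc1)c1nnc(-c2ccccn2)o1`: 5000 nM

Compound 1 stands highest of the two numbers in a functional assay on HUVEC cells (Homo sapiens) for inhibition, read by ELISA; a higher number here means a weaker inhibitor, a lower number a stronger inhibitor. Its nearest neighbour is compound 2, whose value in this assay lies within the scatter of that of compound 1, so the two are not distinguished by these data. Compound 3, `COc1c(C)cnc(C[S+]([O-])c2nnc(-c3ccccc3O)o2)c1C`, has not yet been measured. It differs from compound 1 in one place: 2-hydroxyphenyl in place of propyl on an aromatic carbon. Going by the values given here, no measured pair shows the effect of such a change, so the expected size of the step is set without a direct precedent. With both known values lying close together and weak, only a modest move is expected, with a slight lean toward a lower number, but a result within the scatter is as likely as one beyond it. For compound 3 the estimated step is a 2.0-fold lower number from compound 1 to compound 3 (0.30 log units; within the scatter), and its value in this assay is expected to be around 5000 nM, between 1500 nM and 15000 nM.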

Compound 3, half-maximal inhibitory concentration: 10000 nM
Beside the measured number, compound 3's estimate is 2.0-fold (0.30 log units) below it, within the range that was stated.
By their numbers in this assay, from the lowest: compounds 2, 1 and 3 (each within the scatter of the next).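

Going by these compounds alone, putting 2-hydroxyphenyl in place of propyl on this aromatic carbon gives no change at the digits printed from compound 1 to compound 3 (within the scatter) in this assay, and this pair is the first direct reading of a change at this position. It shows that the larger group, which brings an aromatic ring and a hydrogen-bond donor, does not separate compound 3 from compound 1 in this assay, so this exchange yields no stronger inhibitor on the core of compound 1. Nothing available accounts for this result.

The compounds shown leave open whether another group at this position, such as an amine, a carboxylic acid or a longer chain, would move the number beyond the scatter. Equally open, as far as these compounds go, is how plain phenyl on the core of compound 1 would compare with the 2-hydroxyphenyl of compound 3.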